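This account rests on a few compounds, and the source may have more. Where it says the series, first, only, none or still open, it means among the compounds named here.

Measured in an ADME assay on NIH3T3 cells (Mus musculus) for cytotoxicity, read by MTT assay, with a stated time of 24 h; on this read-out lower numbers stand for stronger inhibition and higher numbers for weaker inhibition:
compound 1 `Cn1cnnc1SCC(=O)N/N=c1/scc(-c2ccc([N+](=O)[O-])cc2)n1-c1ccccc1` gives 133 ug/mL
compound 2 `O=C(CSc1ncccn1)N/N=c1/scc(-c2ccc([N+](=O)[O-])cc2)n1-c1ccccc1` gives 193 ug/mL

Compound 1 holds the lowest of the two numbers; its nearest neighbour is compound 2, and the step of a 1.5-fold higher number from compound 1 to compound 2 (0.16 log units; within the scatter) changes the heterocycle on the sulfur only. Compound 3 `Cn1cnnc1SCC(=O)N/N=c1/scc(-c2ccc(Br)cc2)n1-c1ccccc1` differs from compound 1 by bromo in place of nitro on an aromatic carbon. For the measured compounds named here, no measured step touches this part of the shared core, so nothing in the two values speaks for a change in this assay beyond the scatter. Compound 3 is therefore expected near compound 1, with the step of a 1.1-fold higher number from compound 1 to compound 3 (0.02 log units; within the scatter) taken as an estimate only, at 140 ug/mL within 70 ug/mL to 280 ug/mL.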

Compound 3, half-maximal inhibitory concentration: 58.3 ug/mL
Estimate against measurement, compound 3: 2.4-fold (0.38 log units) above; measured number outside the range, below it.
By their numbers in this assay, from the lowest: compound 3; then compounds 1 and 2 (each within the scatter of the next).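

In this assay the aromatic carbon carrying the nitro group responds to substitution: bromo in place of nitro gives a 2.3-fold lower number from compound 1 to compound 3 (0.36 log units; beyond the scatter), a modest step but beyond the scatter. For the compounds shown here, the earlier change of heterocycle on the sulfur stayed within the scatter, so this is the first single change to separate two compounds. Nothing available bears on the reason for this step.

Going by these compounds, whether 4-bromophenyl gives a similar step with pyrimidin-2-yl on the sulfur remains open. So does how an amine or a methoxy group would read at this position.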